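A Methyl for a Fluoro on a Weakly Active Scaffold

The source may report more compounds than this note shows. Statements on the series, on what has been measured and on what is new or still open speak of the compounds shown alone.

Measured so far in a functional assay on HCT-116 cells (Homo sapiens) for inhibition, read by sulforhodamine B assay, with a stated time of 48 h; a higher number here means a weaker inhibitor, a lower number a stronger inhibitor:
Compound 1, `CCOC(=O)CCO/N=C(/c1ccc(OC)c(OC)c1OC)c1cccc2ccccc12`, gives 10000 nM.
Compound 2, `COc1ccc(C(O)(Cc2ccc(F)cc2)c2cccc3ccccc23)c(OC)c1OC`, gives > 20000 nM, which is a limit of the assay and not a number.
Compound 3, `COc1cc(COC(c2ccc(OC)c(OC)c2OC)c2cccc3ccccc23)cc(OC)c1`, gives > 20000 nM, again a limit of the assay rather than a measured number.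

Compound 2 thus stands at the limit of > 20000 nM in this assay, at which 2 of the 3 values shown sit; nothing finer is known of it than that it was not active enough to be read within the range of this assay. Among the three measured compounds no two differ in only one place, so no measured step is available to lean on.

The step from compound 2 to compound 4 is a single change: methyl in place of fluoro on an aromatic carbon. Compound 4 is `COc1ccc(C(O)(Cc2ccc(C)cc2)c2cccc3ccccc23)c(OC)c1OC` and has not yet been measured in this assay.

Without a measured step of this kind, the expectation rests on compound 2 alone. The step from compound 2 to compound 4 is expected to be a number no higher from compound 2 to compound 4 (the limit leaves the size open), that is, none beyond the usual scatter, because compound 2 already sits at the limit of > 20000 nM in this assay, at which 2 of the 3 values shown sit, and one small exchange on an aromatic carbon is not expected to move it far. Compound 4 is therefore expected to give 20000 nM in this assay, with a range from 8000 nM to 50000 nM, and most likely it too will be reported only as a limit.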

Compound 4, half-maximal inhibitory concentration: > 20000 nM
Compound 4: a limit, no number (the forecaster's own chance of this, stated with the estimate: 65%); the middle value lies on the limit itself.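

In this assay compound 4 gives > 20000 nM, a limit of the assay and not a number. Compound 2 is also reported only as a limit, so no step can be read between compound 2 and compound 4. The compounds shown leave open whether methyl in place of fluoro changes the inhibition at all.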